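The source may hold more compounds than are shown below. What is called first, only, known or untested is meant among the compounds shown, and "the series" means these compounds.

Measured so far in a physicochemical assay for solubility, in phosphate buffer, at pH 7.2; on this read-out higher numbers stand for higher solubility and lower numbers for lower solubility
- compound 1 `COc1cc(C2CN(C(=O)c3cc(OC[C@@H](O)CO)ccn3)C2)ccc1OCc1ccc(C2CC2)cc1` gives 3100 nM
- compound 2 `CCc1ccc(COc2ccc(C3CN(C(=O)c4cc(COC[C@@H](O)CO)ccn4)C3)cc2OC)cc1` gives 7100 nM

Compound 1 stands lowest of the two, and the gap up to compound 2 lies beyond the usual scatter. Compound 3 `COc1cc(C2CN(C(=O)c3cc(COC[C@H](O)CO)ccn3)C2)ccc1OCc1ccc(C2CC2)cc1` is still unmeasured. It differs from compound 1 by (2,3-dihydroxypropoxy)methyl in place of 2,3-dihydroxypropoxy on an aromatic carbon in the shape of (2,3-dihydroxypropoxy)methyl in place of 2,3-dihydroxypropoxy on an aromatic carbon, opposite the ring nitrogen. Among the measured compounds shown here, no two measured compounds differ in one place only, so no measured step sizes this change. In this assay a small rise is expected, possibly none beyond the scatter, resting only on the higher value of compound 2 (7100 nM) against compound 1 (3100 nM). The expected step is a 1.5-fold higher number from compound 1 to compound 3 (0.16 log units; within the scatter) in size. For compound 3 the estimate is 4500 nM with an expected range (1600 nM to 12000 nM).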

Compound 3, solubility: 6700 nM
The estimate for compound 3 lay 1.5-fold (0.17 log units) below the measured number; the range from low to high includes it.
By their numbers in this assay, from the lowest: compound 1; then compounds 3 and 2 (each within the scatter of the next).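

In this assay, the place on the aromatic ring opposite the ring nitrogen proves sensitive to a small change in the chain: (2,3-dihydroxypropoxy)methyl in place of 2,3-dihydroxypropoxy gives a 2.2-fold higher number from compound 1 to compound 3 (0.33 log units; beyond the scatter). Among the compounds shown here, this is the first single-place comparison, and it sizes the change as modest. The two groups carry the same counts of hydrogen-bond donors and acceptors, and nothing at hand accounts for the step.

On these data alone, whether an amine or a carboxylic acid at this place, or a chain longer than (2,3-dihydroxypropoxy)methyl, would move the number further remains open. The step is also known only on the core of compound 1, so its size with other groups elsewhere on the molecule is undetermined.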